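Pyridin-3-yl for Thiophen-2-yl: What Compound 4 Should Give

The compounds below may be only part of what the source reports. "The series", "measured", "known", "first", "only" and "open" are said of these compounds alone.

Compound 1 `c1cc(Nc2nccc(-c3cccnc3)n2)cc(OCCn2ccnc2)c1`: 100 nM
Compound 2 `c1cc(Nc2nccc(-c3cccs3)n2)cc(OCCn2ccnc2)c1`: 100 nM
Compound 3 `COc1ccc(Nc2nccc(-c3cccs3)n2)cc1`: 3900 nM

Of the compounds shown here, three have been measured in a functional assay for inhibition, with Homo sapiens as the target; a lower number here means a stronger inhibitor, a higher number a weaker inhibitor. Compound 1 `c1cc(Nc2nccc(-c3cccnc3)n2)cc(OCCn2ccnc2)c1` gives 100 nM, and compound 2 `c1cc(Nc2nccc(-c3cccs3)n2)cc(OCCn2ccnc2)c1` gives 100 nM. These two share one core and differ in a single group: pyridin-3-yl in place of thiophen-2-yl on an aromatic carbon. The step of no change at the digits printed from compound 2 to compound 1 (within the scatter). Compound 3 `COc1ccc(Nc2nccc(-c3cccs3)n2)cc1` gives 3900 nM in this assay, the highest number of the three. How its core differs from the core of compound 2 is not broken down here; the two values simply show compound 3 as the far weaker inhibitor.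

Compound 4 `COc1ccc(Nc2nccc(-c3cccnc3)n2)cc1` has not yet been measured. It differs from compound 3 in one place: pyridin-3-yl in place of thiophen-2-yl on an aromatic carbon. Within the data shown here, this is the same kind of change as the one from compound 2 to compound 1, though not the same: the place is described in one case as meta to a group of 9 heavy atoms and in the other as meta to a large group. Because the step of no change at the digits printed from compound 2 to compound 1 (within the scatter) stayed within the scatter, compound 4 is expected to stand close to compound 3, with an expected step of a 1.1-fold lower number from compound 3 to compound 4 (0.05 log units; within the scatter). This rests on a single prior example on a different core, so the expectation is held loosely. For compound 4 the estimate in this assay is 3500 nM, expected to fall between 1200 nM and 10000 nM.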

Compound 4, half-maximal inhibitory concentration: 1700 nM
For compound 4 the middle estimate is 2.1-fold (0.31 log units) above the measured one; low and high end bracket the measured number.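

In this assay, putting pyridin-3-yl in place of thiophen-2-yl on the core of compound 3 gives a 2.3-fold lower number from compound 3 to compound 4 (0.36 log units; beyond the scatter), a modest step, while the same change on the core of compound 2 gives no change at the digits printed from compound 2 to compound 1 (within the scatter). Although only the first of these steps lies beyond the scatter, the gap between the two does not, so the two cores cannot be told apart in their response to this change: the same change on two cores in this assay, no change at the digits printed (within the scatter) from compound 2 to compound 1 and a 2.3-fold lower number (0.36 log units; beyond the scatter) from compound 3 to compound 4, 2.3-fold (0.36 log units) apart, within the scatter of two such steps This shows that, on these two cores, the exchange of thiophen-2-yl for pyridin-3-yl carries over with no measurable difference in its effect, but it does not show that the step has one fixed size, and two cores are too few to support a rule for the rest of the series.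

The compounds shown leave open whether the same step would appear on a core bearing an amine or a carboxylic acid in place of the methoxy group. They also leave open how a phenyl or furan-2-yl ring would compare with thiophen-2-yl and pyridin-3-yl at this place on either core.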